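Aryl exchange on the carbonyl carbon

The source may report more compounds than this note shows. Statements on the series, on what has been measured and on what is new or still open speak of the compounds shown alone.

Three compounds have numbers in a functional assay on SK-MEL-5 cells (Homo sapiens) for cytotoxicity, read by sulforhodamine B assay, with a stated time of 48 h, tested at 0.1 uM; a lower number here means a stronger effect, a higher number a weaker effect of the compound at the concentration tested. Compound 1 `COc1cc(-c2cc(/C=C/C(=O)c3ccc(N)cc3)[nH]n2)cc(OC)c1OC` gives 95%. Compound 2 `COc1cc(-c2cc(/C=C/C(=O)c3ccc(Cl)c(Cl)c3)[nH]n2)cc(OC)c1OC` gives 97%. Compound 3 `COc1ccc(-c2cc(/C=C/C(=O)c3cc(OC)c(OC)c(OC)c3)[nH]n2)cc1OC` gives 102%. The number of compound 2 is the second highest of the three shown, with compound 1 nearest and compound 3 furthest, both within the scatter. Going by the values given here, the one single-point step measured, a number 2 percentage points higher from compound 1 to compound 2 (within the scatter), lay within the scatter.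

Compound 4 `COc1ccc(C(=O)/C=C/c2cc(-c3cc(OC)c(OC)c(OC)c3)n[nH]2)cc1` is not yet measured. It differs from compound 2 as follows: 4-methoxyphenyl in place of 3,4-dichlorophenyl on a carbonyl carbon. Among the compounds with values here, the only step that bears on it is the exchange of the ring on the carbonyl carbon, a number 2 percentage points higher from compound 1 to compound 2 (within the scatter), which stayed within the scatter; compound 3, carrying yet another ring on that carbon, gives 102%. No step beyond the scatter is therefore expected in this assay; the expected step is a number 1 percentage points higher from compound 2 to compound 4 (within the scatter). Compound 4 is estimated at 98%, range 88% to 108%.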

Compound 4, a percentage reported as activity, at one concentration (the size of the read-out at that concentration, not a potency): 99%
Beside the measured number, compound 4's estimate is 1 percentage points below it, and the stated range covers the measured number.
By their numbers in this assay, from the lowest: compounds 1, 2, 4 and 3 (each within the scatter of the next).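

In this assay the carbonyl carbon now carries 4-methoxyphenyl as well as 3,4-dichlorophenyl, and the exchange gives a number 2 percentage points higher from compound 2 to compound 4 (within the scatter) and so does not separate the two groups. Methoxy in place of amino on an aromatic carbon gives a number 4 percentage points higher from compound 1 to compound 4 (within the scatter) and also separates nothing, so a change on the ring itself adds no step beyond the scatter at this concentration. Nothing measured accounts for this flat result.

As far as these compounds go, whether a carboxylic acid or a longer chain on that ring would move the number remains open. Also open, from the compounds shown here alone, is whether these compounds would separate at a higher concentration.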